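A few compounds are considered here, and "the series" means these few. Any claim that something is new, unique, unknown or untested is made for them only; others in the source may bear on it.

Compound 2 `Cc1cc(O)c(C2=NN(c3ccc(S(N)(=O)=O)cc3)C(/C=C/c3ccccc3)C2)cc1Cl` gives 68700 nM in a functional assay on IGROV-1 cells (Homo sapiens) for antiproliferative activity, with a stated time of 48 h; a lower number here means that less compound is tolerated, a higher number that more compound is tolerated. For the measured compounds named here, the only other measured compound, compound 1 `Cc1cc(O)c(C2=NN(c3ccc(S(N)(=O)=O)cc3)C(c3ccccc3Cl)C2)cc1Cl`, gives 47200 nM in this assay, and a 1.5-fold higher number from compound 1 to compound 2 (0.16 log units; within the scatter) shows that these two numbers lie within the scatter of each other. Compound 3 `COc1ccc(C2CC(c3cc(Cl)c(C)cc3O)=NN2c2ccc(S(N)(=O)=O)cc2)c(OC)c1OC` differs from compound 2 by 2,3,4-trimethoxyphenyl in place of 2-phenylethenyl on a saturated ring carbon. Going by the values given here, that single measured step at the same ring carbon is the only guide, and it did not move this assay beyond the scatter, so the expected step for compound 3 is a 1.7-fold lower number from compound 2 to compound 3 (0.23 log units; within the scatter). Compound 3 is therefore estimated at 40000 nM, with a range from 10000 nM to 150000 nM.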

Compound 3, concentration lethal to 50% of the cells: 26800 nM
The estimate for compound 3 lay 1.5-fold (0.17 log units) above the measured number, within the range that was stated.
By their numbers in this assay, from the lowest: compounds 3, 1 and 2 (each within the scatter of the next, the first and the last beyond it).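

In this assay, changing the group on this saturated ring carbon can now move the number beyond the scatter: 2,3,4-trimethoxyphenyl in place of 2-phenylethenyl gives a 2.6-fold lower number from compound 2 to compound 3 (0.41 log units; beyond the scatter), a modest step. The same group in place of 2-chlorophenyl gives a 1.8-fold lower number from compound 1 to compound 3 (0.25 log units; within the scatter), so the change shows only against 2-phenylethenyl. No measurement at hand gives a reason for this step. Going by these compounds, what an amine or a carboxylic acid on this ring carbon would do stays open, as does whether the three methoxy groups of compound 3 matter at all.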